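The source may report more compounds than this note shows. Statements on the series, on what has been measured and on what is new or still open speak of the compounds shown alone.

Measured so far:
Compound 1 `CN1CCC[C@@H]1Cn1nc(Cc2cccc(Cl)c2)c2ccccc2c1=O` — in an assay for binding affinity to Alpha-1A adrenergic receptor (Homo sapiens) (a higher number here means a weaker inhibitor, a lower number a stronger inhibitor), compound 1 gives 398 nM.
Compound 2 `CN(C)CCn1nc(Cc2ccc(Cl)cc2)c2ccccc2c1=O` — in this assay compound 2 gives 158 nM.

Compound 1 holds the higher of the two numbers; compound 2 sits at a lower value, beyond the scatter. Compound 3 `COc1cccc(Cc2nn(C[C@H]3CCCN3C)c(=O)c3ccccc23)c1` differs from compound 1 by methoxy in place of chloro on an aromatic carbon. Within the data shown here, no measured pair shows this change, so only a modest step is expected, with direction uncertain, likely within the scatter. For compound 3 in this assay the estimate is 500 nM, range 200 nM to 1300 nM, the expected step being a 1.3-fold higher number from compound 1 to compound 3 (0.10 log units; within the scatter).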

Compound 3, inhibition constant: 1580 nM
Beside the measured number, compound 3's estimate is 3.2-fold (0.50 log units) below it; the whole stated range lies below it.
By their numbers in this assay, from the lowest: compound 2; then compound 1; then compound 3.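

In this assay, among these compounds, the change from 3-chlorophenyl to 3-methoxyphenyl gives a 4.0-fold higher number from compound 1 to compound 3 (0.60 log units; beyond the scatter) as the first comparison that differs in one place. This aromatic position, meta to a large group, therefore responds to the choice of group, and chloro gives the lower number of this pair. Nothing measured here bears on the reason for this step.

Still open, from the compounds shown here alone, is whether fluoro, methyl or trifluoromethyl at this position would stay close to compound 1 or move further from it. Also open, going by these compounds, is whether a hydroxy group or an amine there would give a number above that of compound 3.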